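The source may report more compounds than this note shows. Statements on the series, on what has been measured and on what is new or still open speak of the compounds shown alone.

Compound 1 `CC1(C)Oc2ccc(C#N)cc2[C@@H](/N=C(\NC#N)Sc2ccccc2)[C@@H]1O`: 4900 nM
Compound 2 `CC1(C)Oc2ccc(C#N)cc2[C@@H](/N=C(\NC#N)NCc2ccccc2)[C@@H]1O`: 2400 nM
Compound 3 `CC1(C)Oc2ccc(C#N)cc2[C@@H](/N=C(\NC#N)Nc2ccc(N)cc2)[C@@H]1O`: 3500 nM
Compound 4 `CC1(C)Oc2ccc(C#N)cc2[C@@H](/N=C(\NC#N)Nc2cccc([N+](=O)[O-])c2)[C@@H]1O`: not yet measured

All values come from a functional assay (aorta) with Rattus norvegicus as the target; on this read-out higher numbers stand for weaker inhibition and lower numbers for stronger inhibition. Compound 3 stands within the scatter of both other measured compounds: a 1.4-fold lower number from compound 1 to compound 3 (0.15 log units; within the scatter), and a 1.5-fold higher number from compound 2 to compound 3 (0.16 log units; within the scatter). The next change is 3-nitrophenyl in place of 4-aminophenyl on an amine nitrogen. In short, 3-nitrophenyl replaces 4-aminophenyl on an amine nitrogen. Going by the values given here, no measured compound carries 3-nitrophenyl, so the evidence is indirect. The measured steps at this place are small, and the largest is modest: a 2.0-fold lower number from compound 1 to compound 2 (0.31 log units; beyond the scatter). No step beyond the scatter is therefore expected in this assay, and no direction is favoured. The estimated step is a 1.2-fold lower number from compound 3 to compound 4 (0.07 log units; within the scatter). Compound 4 is expected at 3000 nM, with an estimated range of 1100 nM to 8000 nM.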

Compound 4, half-maximal inhibitory concentration: 670 nM
Beside the measured number, compound 4's estimate is 4.5-fold (0.65 log units) above it; measured number below the stated range.
By their numbers in this assay, from the lowest: compound 4; then compounds 2, 3 and 1 (each within the scatter of the next, the first and the last beyond it).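

In this assay, the aryl group on this amine nitrogen proves able to move the number beyond the scatter: 3-nitrophenyl in place of 4-aminophenyl gives the largest single change so far (a 5.2-fold lower number from compound 3 to compound 4 (0.72 log units; beyond the scatter)). The lower number also holds against benzyl (a 3.6-fold lower number from compound 2 to compound 4 (0.55 log units; beyond the scatter)) and against phenylsulfanyl (a 7.3-fold lower number from compound 1 to compound 4 (0.86 log units; beyond the scatter)), leaving compound 4 lowest of the four. No measurement shown here accounts for this step.

The change alters both the substituent and where it sits, so the two remain unseparated. Plain phenyl, or phenyl carrying a trifluoromethyl group or a carboxylic acid, would show whether the nitro group itself matters.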